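The source may hold more compounds than are shown below. What is called first, only, known or untested is meant among the compounds shown, and "the series" means these compounds.

The measured compounds:
compound 1 `C/N=C(\S)OC[C@H]1OC(n2cnc3c(NC4CCOC4)nc(Cl)nc32)[C@H](O)[C@@H]1O`: 71 nM
compound 2 `CCCNC(=O)OC[C@H]1OC(n2cnc3c(NC4CCOC4)ncnc32)[C@H](O)[C@@H]1O`: 235 nM

In an assay on DDT1 cells (Cricetulus griseus) for binding affinity to adenosine receptor A1 (Homo sapiens), read by radioligand binding (on this read-out lower numbers stand for stronger inhibition and higher numbers for weaker inhibition), compound 1 gives 71 nM, and compound 2 gives 235 nM, the higher of the two numbers, with a gap that lies beyond the scatter. Compound 1 differs from compound 2 in more than one place, so the two values alone do not show which difference carries the gap. Compound 3 `CC(C)/N=C(\S)OC[C@H]1OC(n2cnc3c(NC4CCOC4)ncnc32)[C@H](O)[C@@H]1O` has not yet been measured. It differs from compound 2 by a group of 6 heavy atoms (4 carbon, 1 nitrogen, 1 sulfur; no ring) in place of a group of 6 heavy atoms (4 carbon, 1 nitrogen, 1 oxygen; no ring), on an oxygen on a saturated carbon. Within the data shown here, no measured pair shows this change on its own, so no step of known size guides the expectation. Because compound 1 gives 71 nM and also carries a group holding sulfur at the same oxygen, a somewhat lower number is expected for compound 3, though it may stay within the scatter of compound 2. The expected step in this assay is a 2.0-fold lower number from compound 2 to compound 3 (0.29 log units; within the scatter). Compound 3 is estimated at 120 nM, with a range from 40 nM to 400 nM.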

Compound 3, inhibition constant: 36 nM
Compound 3: the middle estimate sits 3.3-fold (0.52 log units) above what was measured; measured number below the stated range.
By their numbers in this assay, from the lowest: compounds 3 and 1 (each within the scatter of the next); then compound 2.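

Compound 2 and compound 3 differ in one place only, so this pair isolates a change that compound 1 could not, as it differs from compound 2 in more than one place. In this assay, exchanging propylcarbamoyl for the sulfur-holding group on an oxygen on a saturated carbon gives a 6.5-fold lower number from compound 2 to compound 3 (0.81 log units; beyond the scatter), even though both groups have 6 heavy atoms and the same hydrogen-bond donor and acceptor counts, so this position responds to a change that leaves those counts untouched. No measurement shown accounts for the step.

The compounds shown leave open whether sulfur or the branching of the chain carries the step, since isopropylcarbamoyl, which would separate the two, is not among them. As far as these compounds go, how a longer chain on the sulfur-holding group would read also remains open.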